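The source may report more compounds than this note shows. Statements on the series, on what has been measured and on what is new or still open speak of the compounds shown alone.

Measured in a functional assay on HepG2 cells (Homo sapiens) for inhibition, read by MTT assay, with a stated time of 24 h; a higher number here means a weaker inhibitor, a lower number a stronger inhibitor:
- Compound 1 `CC1(C)[C@H]2CC[C@]1(C)N(Cc1cn(-c3cccc(F)c3)nn1)C(=O)C2`: 80 nM
- Compound 2 `CC1(C)[C@H]2CC[C@]1(C)N(Cc1cn(-c3ccccc3Br)nn1)C(=O)C2`: 150 nM
- Compound 3 `CC1(C)[C@H]2CC[C@]1(C)N(Cc1cn(-c3ccccc3O)nn1)C(=O)C2`: 120 nM

Compound 3 is not separated from the other two compounds, with a 1.5-fold higher number from compound 1 to compound 3 (0.18 log units; within the scatter) and a 1.3-fold lower number from compound 2 to compound 3 (0.10 log units; within the scatter). Compound 4 `CC1(C)[C@H]2CC[C@]1(C)N(Cc1cn(-c3cccc(O)c3)nn1)C(=O)C2` keeps the shared core and differs from it in one place: 3-hydroxyphenyl in place of 2-hydroxyphenyl on an aromatic nitrogen. All the measured changes at this group stayed small, the largest being a 1.9-fold higher number from compound 1 to compound 2 (0.27 log units; within the scatter). Going by the values given here, no measured step isolates the move of the hydroxy group itself. With nothing beyond the scatter among these compounds, no clear shift in either direction is expected in this assay. The step expected is a 1.2-fold lower number from compound 3 to compound 4 (0.08 log units; within the scatter). Compound 4 is estimated at 100 nM, with an expected range of 50 nM to 220 nM.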

Compound 4, half-maximal inhibitory concentration: 70 nM
Estimate against measurement, compound 4: 1.4-fold (0.15 log units) above, within the range that was stated.
By their numbers in this assay, from the lowest: compounds 4, 1, 3 and 2 (each within the scatter of the next, the first and the last beyond it).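

In this assay, moving the hydroxy group from 2-hydroxyphenyl to 3-hydroxyphenyl does not separate the two compounds (a 1.7-fold lower number from compound 3 to compound 4 (0.23 log units; within the scatter)), and the change from fluoro to hydroxy does not either (a 1.1-fold lower number from compound 1 to compound 4 (0.06 log units; within the scatter)). Going by these compounds alone, only 3-hydroxyphenyl in place of 2-bromophenyl passes the scatter, and only modestly (a 2.1-fold lower number from compound 2 to compound 4 (0.33 log units; beyond the scatter)), the first step at this position to do so. Nothing available explains these numbers. The compounds shown leave open whether an amine or a carboxylic acid on the phenyl group would shift the number more clearly.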